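The source may hold more compounds than are shown below. What is called first, only, known or untested is meant among the compounds shown, and "the series" means these compounds.

Measured compounds:
- Compound 1, `C=C1CCC(c2csc(/C=C(\C)C(N)=O)c2)CC1`. In an ADME assay on NIH3T3 cells (Mus musculus) for cytotoxicity, read by CCK-8 assay, with a stated time of 24 h (a higher number here means a weaker inhibitor, a lower number a stronger inhibitor), compound 1 gives > 50000 nM, which is a limit of the assay and not a number.
- Compound 2, `C/C(=C\c1cc(-c2ccccc2)co1)C(N)=O`. In this assay compound 2 gives > 50000 nM, again a limit of the assay rather than a number.

Compound 2 therefore stands nowhere definite on the numbers shown: for it only a limit is known, and the one further value in this assay is a limit as well, so both shown values sit at the limit of > 50000 nM in this assay, at which 2 of the 2 values shown sit. Among the measured compounds shown here, no step between measured compounds can be drawn, and no pair differs in one place.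

Compound 3, `C/C(=C\c1cc(-c2ccc(C)cc2)co1)C(N)=O`, is the next compound to be measured in this assay. It differs from compound 2 by methyl in place of hydrogen on an aromatic carbon, para to a large group. With nothing measured against this change, no step beyond the scatter is expected in this assay, and the expected step is a step that the limit leaves unreadable from compound 2 to compound 3. For compound 3 the expected result in this assay is 60000 nM, with a range from 30000 nM to 200000 nM, most likely reported only as a limit once more.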

Compound 3, half-maximal inhibitory concentration: > 50000 nM
Compound 3 ended at the assay's limit; the forecaster's own chance of this, stated with the estimate: 85%; the middle value is on the limit's open side.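

Compound 2 and compound 3 both end at a limit of the assay and not at a number, so no step can be read for methyl in place of hydrogen on an aromatic carbon in this assay and the comparison stops here: the limit of > 50000 nM in this assay, at which 3 of the 3 values shown sit.

The compounds shown leave open whether any member of the series gives a readable number in this assay and how a change to the shared core would show there.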